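The source may hold more compounds than are shown below. What is called first, only, known or untested is meant among the compounds shown, and "the series" means these compounds.

Compound 1 `CC(=O)CC/C=C(\C)CCC1=C(C)CCCC1(C)C`: in a functional assay on A498 cells (Homo sapiens) for inhibition (on this read-out higher numbers stand for weaker inhibition of growth and lower numbers for stronger inhibition of growth), compound 1 gives > 15000 nM, a limit of the assay rather than a number.
Compound 2 `C=C1CCCC(C)(C)C1CC[C@]1(C)CC[C@@H]([C@@H](C)C(=O)O)OO1`: in this assay compound 2 gives > 10000 nM, likewise a limit.

Among the compounds with values here, compound 2 therefore stands at the limit of > 10000 nM in this assay, at which 1 of the 2 values shown sits, and the only other value shown is at the limit of > 15000 nM in this assay, at which 1 of the 2 values shown sits. Within the data shown here, no step between measured compounds is available. Compound 3 `C=C1CCCC(C)(C)C1CC[C@@]1(C)CC[C@H]([C@@H](C)C(=O)O)OO1` differs from compound 2 in that (the two compounds have the same atoms and bonds; at least one stereo element is drawn with a configuration in one of them and without one in the other: 2 of 4 stereo elements differ; a stereocentre at a saturated ring carbon is drawn R in compound 2 and S in compound 3; a stereocentre at a saturated ring carbon is drawn S in compound 2 and R in compound 3). With the same atoms and bonds and only mirrored ring stereocentres, the step from compound 2 to compound 3 is expected to be none beyond the scatter, a step that the limit leaves unreadable from compound 2 to compound 3. Compound 3 is thus estimated at 15000 nM, with a range of 4000 nM to 50000 nM.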

Compound 3, concentration for 50% growth inhibition: > 12500 nM
Compound 3 was reported as a limit (the forecaster's own chance of this, stated with the estimate: 80%); the middle value does not contradict the limit.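

Compound 2 and compound 3 are both reported only as limits, so no step can be read between them. From the compounds shown here alone, what swapping the two ring stereocentres does to growth inhibition stays open.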